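The compounds below may be only part of what the source reports. "The series", "measured", "known", "first", "only" and "open" are said of these compounds alone.

Working notes on the series.

Three compounds share an amide linking a piperidine to a bicyclic aniline, with an aryl group on the piperidine nitrogen. Compound 1 `O=C1CSc2ccc(NC(=O)C3CCN(c4cc(F)c(F)c(F)c4)CC3)cc2N1` gives 1960 nM in a functional assay for antagonist activity at transient receptor potential cation channel subfamily V member 1 (Homo sapiens), read by FLIPR and calcium flux; on this read-out higher numbers stand for weaker inhibition and lower numbers for stronger inhibition. Compound 3 `O=C1COc2ccc(NC(=O)C3CCN(c4ccccc4Br)CC3)cc2N1` gives 160 nM in this assay, the lowest of the two numbers reported; compound 1 sits a good deal higher, and that gap lies beyond the scatter. Compound 2 `O=C(Nc1ccc2cc[nH]c2c1)C1CCN(c2cccc(C(F)(F)F)c2)CC1` gives only a limit in this assay, > 9000 nM, and no number. That limit is the limit of > 9000 nM in this assay, at which 1 of the 3 values shown sits, the point at which the assay stops reporting a value.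

Compound 4 `CC(C)c1ccccc1N1CCC(C(=O)Nc2ccc3c(c2)NC(=O)CO3)CC1` is not yet measured. Relative to compound 3 the change is isopropyl in place of bromo on an aromatic carbon. Within the data shown here, no measured pair shows this change, so there is nothing to scale it against. The step from compound 3 to compound 4 is expected to be small, a 1.8-fold higher number from compound 3 to compound 4 (0.24 log units; within the scatter), likely within the scatter and if anything toward a weaker number. Compound 4 is therefore estimated at 280 nM, with a range from 90 nM to 900 nM.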

Compound 4, half-maximal inhibitory concentration: 180 nM
For compound 4 the middle estimate is 1.6-fold (0.19 log units) above the measured one; the measured number falls inside the stated range.
By their numbers in this assay, from the lowest: compounds 3 and 4 (each within the scatter of the next); then compound 1. At a limit, above all of these: compound 2.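

Among these compounds, this is the first step that can be read, since compounds 1 to 3 differ from one another in more than one place: in this assay, the change gives a 1.1-fold higher number from compound 3 to compound 4 (0.05 log units; within the scatter). On an aromatic carbon ortho to a large group, 2-bromophenyl and 2-isopropylphenyl cannot be told apart, even though the group goes from 1 heavy atom to 3 heavy atoms, neither with a hydrogen-bond donor or acceptor. Nothing at hand gives a reason for this result.

Open, going by these compounds, is whether an amine or a carboxylic acid at the same place would keep the number in this assay. Also open, on these data alone, is whether the same exchange would read alike on the core of compound 1.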